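A second chlorine on a pyridazine aryl piece

The source may hold more compounds than are shown below. What is called first, only, known or untested is meant among the compounds shown, and "the series" means these compounds.

Of the compounds shown here, three have been tested in a functional assay on the whole organism with Mus musculus as the target; on this read-out lower numbers stand for an effect already at smaller amounts and higher numbers for an effect only at larger amounts of compound. Compound 1, `Cc1ccccc1-c1ccc(N2CCC(O)CC2)nn1`, gives 40 mg/kg. Compound 2, `Cc1cc(Cl)ccc1-c1ccc(N2CCC(O)CC2)nn1`, gives 10 mg/kg. Among the measured compounds shown here, the only change between them is chloro in place of hydrogen on an aromatic carbon, and it brought a 4.0-fold lower number from compound 1 to compound 2 (0.60 log units; beyond the scatter). Compound 3, `CNC(=O)OC1CCN(c2ccc(-c3ccccc3Cl)nn2)CC1`, gives 13 mg/kg; how its core differs from that of compound 1 is not broken down here.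

Compound 4, `CNC(=O)OC1CCN(c2ccc(-c3ccc(Cl)cc3Cl)nn2)CC1`, has not been measured. It differs from compound 3 by chloro in place of hydrogen on an aromatic carbon. In compound 2 the new chlorine sits meta to a methyl group, in compound 4 meta to a chloro group, so this is the same kind of change as before, not the same change. Because the earlier one gave a 4.0-fold lower number from compound 1 to compound 2 (0.60 log units; beyond the scatter), a similar improvement is expected here, though a single example is a thin basis. Compound 4 is therefore expected to give about 4 mg/kg, most likely between 1.5 mg/kg and 12 mg/kg. The step this estimate means is a 3.3-fold lower number from compound 3 to compound 4 (0.51 log units; beyond the scatter), an expectation rather than a measurement.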

Compound 4, dose for half-maximal effect: 1.4 mg/kg
The estimate for compound 4 lay 2.9-fold (0.46 log units) above the measured number; measured number below the stated range.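

In this assay, going from 2-chlorophenyl to 2,4-dichlorophenyl gave a 9.3-fold lower number from compound 3 to compound 4 (0.97 log units; beyond the scatter). The same change lowered the number on both cores, and the two steps lie close enough that repeated measurement alone could separate them: the same change on two cores in this assay, a 4.0-fold lower number (0.60 log units; beyond the scatter) from compound 1 to compound 2 and a 9.3-fold lower number (0.97 log units; beyond the scatter) from compound 3 to compound 4, 2.3-fold (0.37 log units) apart, within the scatter of two such steps. So, within these two pairs, the gain from this chlorine carried over from one core to the other, but two pairs are a small sample, and they show neither that the change works on every core in the series nor that it has a larger effect on the core of compound 3 than on the core of compound 1.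

The compounds shown leave open whether another group at this place, such as fluoro, methoxy or a nitrile, would give a similar step. They also leave open whether the chlorine's gain would hold on a third core, for instance one carrying an amine where compound 1 carries its hydroxyl.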